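The source may report more compounds than this note shows. Statements on the series, on what has been measured and on what is new or still open speak of the compounds shown alone.

Compound 1 `O=c1c2ccccc2[se]n1-c1nnc(-c2cc([N+](=O)[O-])cc([N+](=O)[O-])c2)s1`: 17900 nM in a functional assay on A549 cells (Homo sapiens) for antiproliferative activity, read by CCK-8 assay, with a stated time of 48 h; a higher number here means a weaker inhibitor, a lower number a stronger inhibitor
Compound 2 `O=c1c2ccccc2[se]n1-c1nnc(-c2ccccc2[N+](=O)[O-])s1`: 11400 nM in this assay

Compound 2 holds the lower of the two numbers in this assay, but compound 1 stands within the scatter of it, so neither can be ranked above the other. Compound 3 `Cc1ccccc1-c1nnc(-n2[se]c3ccccc3c2=O)s1` differs from compound 2 in one place: methyl in place of nitro on an aromatic carbon. For the measured compounds named here, no measured pair here carries the same change, so nothing is known of its size. A modest step, not clearly beyond the scatter, is expected, with a 1.3-fold lower number from compound 2 to compound 3 (0.10 log units; within the scatter) as the estimated shift. Compound 3 is therefore estimated in this assay at 9000 nM, between 3000 nM and 30000 nM.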

Compound 3, half-maximal inhibitory concentration: 18600 nM
Beside the measured number, compound 3's estimate is 2.1-fold (0.32 log units) below it; the measured number falls inside the stated range.
By their numbers in this assay, from the lowest: compounds 2, 1 and 3 (each within the scatter of the next).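

The exchange of nitro for methyl on an aromatic carbon, ortho to a large group, gives a 1.6-fold higher number from compound 2 to compound 3 (0.21 log units; within the scatter) in this assay, so the two groups cannot be told apart at this position. The nitro, with its hydrogen-bond acceptors, is therefore not required here for a number of this size, since the methyl has none. Nothing available explains this result.

Whether an amine, a carboxylic acid or a methoxy group at this same place would stay within the scatter of these compounds remains open.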